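The source may report more compounds than this note shows. Statements on the series, on what has been measured and on what is new or still open speak of the compounds shown alone.

Measured so far:

Compound 1, `O=C(Nc1ccc(Br)cc1)Nc1ccc(Nc2ncnc3c2OCCN3)cc1` — 2220 nM
Compound 2, `O=C(Nc1ccc(Nc2ncnc3c2OCCN3)cc1)Nc1ccc(C(F)(F)F)cc1` — 306 nM
Compound 3, `O=C(Nc1ccc(Nc2ncnc3c2OCCN3)cc1)Nc1cc(Cl)cc(Cl)c1` — 865 nM

All three share the same core and differ only in the aryl group on the far nitrogen of the urea. In an assay on isolated protein for inhibition of proto-oncogene tyrosine-protein kinase receptor Ret (Homo sapiens), read by 33P incorporation, with stated times of 15 min and 40 min (a lower number here means a stronger inhibitor, a higher number a weaker inhibitor), compound 3 gives 865 nM, the second highest of the three numbers: it sits between the others, with a 2.6-fold lower number from compound 1 to compound 3 (0.41 log units; beyond the scatter) on one side and a 2.8-fold higher number from compound 2 to compound 3 (0.45 log units; beyond the scatter) on the other.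

Compound 4, `O=C(Nc1ccc(Nc2ncnc3c2OCCN3)cc1)Nc1cccc2ccccc12`, differs from compound 3 in one place: naphthalen-1-yl in place of 3,5-dichlorophenyl on an amide-type nitrogen. Going by the values given here, no measured step exchanges a substituted phenyl for a fused two-ring system, so the guidance comes only from the three steps among the substituted phenyls, which were a 7.3-fold lower number from compound 1 to compound 2 (0.86 log units; beyond the scatter), a 2.6-fold lower number from compound 1 to compound 3 (0.41 log units; beyond the scatter) and a 2.8-fold higher number from compound 2 to compound 3 (0.45 log units; beyond the scatter). Each of these changed the number by a modest amount, so a modest step in this assay, in either direction, is the expectation here; the step from compound 3 to compound 4 is estimated as a 1.3-fold lower number from compound 3 to compound 4 (0.12 log units; within the scatter). Compound 4 is therefore expected to give about 650 nM in this assay, within a range of 150 nM to 2800 nM.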

Compound 4, half-maximal inhibitory concentration: > 10000 nM
Compound 4: a limit, no number; the forecaster's own chance of this, stated with the estimate: 3%; middle value at least 15-fold (1.18 log units) away from the limit.
By their numbers in this assay, from the lowest: compound 2; then compound 3; then compound 1. At a limit, above all of these: compound 4.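

Going by these compounds alone, each substituted phenyl on this amide-type nitrogen gave a measurable number in this assay, and the steps among them were modest, so the earlier compounds did not show that one change here could move the number so far. Naphthalen-1-yl does move it that far, whichever compound it is compared with: an at least 11-fold higher number from compound 3 to compound 4 (1.06 log units; beyond the scatter), an at least 32-fold higher number from compound 2 to compound 4 (1.51 log units; beyond the scatter) and an at least 4.5-fold higher number from compound 1 to compound 4 (0.65 log units; beyond the scatter). These sizes are minimums, since the entry for compound 4 is a limit of the assay and not a number, the only such entry here: the limit of > 10000 nM in this assay, at which 1 of the 4 values shown sits.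

From the compounds shown here alone, it stays open whether the drop belongs to fused two-ring groups in general or to naphthalen-1-yl alone. Also open, going by these compounds, is how simpler groups on this nitrogen, such as unsubstituted phenyl or methyl, would behave.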